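Working notes: from methyl to dimethylcarbamoyl

A few compounds are considered here, and "the series" means these few. Any claim that something is new, unique, unknown or untested is made for them only; others in the source may bear on it.

Of the compounds shown here, three sharing one core have numbers so far. In a functional assay (Homo sapiens) (on this read-out higher numbers stand for weaker inhibition and lower numbers for stronger inhibition), compound 2 `Cc1cccc(-c2nccc3nc(N)nn23)c1` gives 5500 nM, the lowest number of the three. Compound 3 `Nc1nc2ccnc(-c3ccncc3)n2n1` reads 18000 nM, a gap from compound 2 that lies beyond the usual scatter. Compound 1 `C#Cc1cccc(-c2nccc3nc(N)nn23)c1` reads 12600 nM; 12600 nM (2 entries) in both of its entries. Among the measured compounds shown here, the data hold no measured step to lean on, so any expectation for a new change rests on these values alone.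

The next compound is compound 4 `CN(C)C(=O)c1cccc(-c2nccc3nc(N)nn23)c1`, which keeps the core of compound 2 and alters one group: dimethylcarbamoyl in place of methyl on an aromatic carbon. This puts dimethylcarbamoyl in place of methyl on an aromatic carbon, meta to a large group.

For the measured compounds named here, the only guide is compound 1, which carries neither methyl nor dimethylcarbamoyl and stands at 12600 nM; 12600 nM (2 entries), a higher number than compound 2 at 5500 nM. A moderate move toward a higher number in this assay, meaning weaker inhibition, is therefore expected, though the evidence is thin and the range stays wide. The expected step is a 2.2-fold higher number from compound 2 to compound 4 (0.34 log units; beyond the scatter). For compound 4 the estimate is 12000 nM, with an expected range of 4000 nM to 36000 nM.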

Compound 4, half-maximal inhibitory concentration: 3500 nM
Beside the measured number, compound 4's estimate is 3.4-fold (0.54 log units) above it; the measured number lies below the stated range.
By their numbers in this assay, from the lowest: compounds 4 and 2 (each within the scatter of the next); then compound 3.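

Notes on the dimethylcarbamoyl change: in this assay, exchanging the methyl group for dimethylcarbamoyl, meta to a large group, gives a 1.6-fold lower number from compound 2 to compound 4 (0.20 log units; within the scatter), so this read-out does not separate the two compounds. This first measured step in the series shows that this position can carry a larger group with a carbonyl and a hydrogen-bond acceptor, neither of which methyl has, without a shift beyond the scatter. No measurement of any property of these compounds bears on the step, and the data offer no explanation for it.

As far as these compounds go, it remains open whether the two methyl groups on the amide nitrogen matter, since a primary carboxamide, an N-methyl carboxamide or a pyrrolidine amide would each test that part of the group on the same core. From the compounds shown here alone, it is also open how far the position accepts other kinds of group, such as a carboxylic acid, an aminomethyl group or a longer chain ending in a hydroxyl, and whether any of them would give a step beyond the scatter.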